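The compounds below may be only part of what the source reports. "The series", "measured", "known", "first", "only" and "open" are said of these compounds alone.

Working notes on the series, read in a functional assay on MCF7 cells (Homo sapiens) for cytotoxicity, read by MTT assay, with a stated time of 72 h; a lower number here means a stronger inhibitor, a higher number a weaker inhibitor. Compound 1 `COc1cccc(/C=C2\CCC/C(=C\c3ccc(Cl)cc3Cl)C2=O)c1OC` is reported in this assay only as a limit, > 20000 nM. Among the measured compounds shown here, compound 2 `COc1ccc(/C=C2\CCC/C(=C\c3cccc(Cl)c3)C2=O)cc1OC` gives 6000 nM in this assay, the only actual number so far.

Still unmeasured is compound 3 `COc1ccc(/C=C2\CCC/C(=C\c3ccccc3Br)C2=O)cc1OC`. Its change from compound 2 is 2-bromophenyl in place of 3-chlorophenyl on a double-bonded chain carbon bound to a double-bonded ring carbon, with the rest of the structure the same. For the measured compounds named here, compound 1 and compound 2 differ in more than one place, and no measured pair isolates a change of this kind.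

Going by the values given here, the expectation therefore rests on compound 2 at 6000 nM, the one number in hand. The estimated 1.3-fold higher number from compound 2 to compound 3 (0.12 log units; within the scatter) is small, stays within the usual scatter, and leans only slightly toward weaker inhibition in this assay. The expected value for compound 3 is 8000 nM, with an estimated range of 3000 nM to 20000 nM.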

Compound 3, half-maximal inhibitory concentration: 9500 nM
For compound 3 the middle estimate is 1.2-fold (0.07 log units) below the measured one; the measured number falls inside the stated range.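

Among the compounds shown here, the step at the double-bonded chain carbon bound to a double-bonded ring carbon gives the first reading of a single change: in this assay, 2-bromophenyl in place of 3-chlorophenyl gives a 1.6-fold higher number from compound 2 to compound 3 (0.20 log units; within the scatter). This one exchange alters both the halogen and its place on the phenyl ring, yet the two compounds cannot be told apart in this read-out. The series therefore now shows that this position accepts a second halogenated phenyl group without a change beyond the scatter, which the earlier pair, differing in more than one place, could not show.

This single step cannot separate the effect of the halogen from that of its place on the ring, and no cause for the result can be drawn from it. Still open is how an amine or a carboxylic acid on this phenyl ring would read, and the series offers only a limit, not a number, for compound 1: the limit of > 20000 nM in this assay, at which 1 of the 3 values shown sits.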